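Methoxy for hydrogen on the lactam series

The compounds below may be only part of what the source reports. "The series", "measured", "known", "first", "only" and "open" are said of these compounds alone.

Compound 1, with the structure `COc1cc(/C=C/C2CC=CC(=O)O2)cc(OC)c1`, carries a lactone core with two methoxy groups; in an ADME assay on HaCaT cells (Homo sapiens) for inhibition, read by sulforhodamine B assay, with a stated time of 48 h (on this read-out lower numbers stand for stronger inhibition of growth and higher numbers for weaker inhibition of growth), compound 1 gives 8.8 uM. Compound 2, with the structure `O=C1C=CCC(/C=C/c2ccccc2)N1`, is the unsubstituted lactam of the series. In this assay compound 2 reaches only the limit > 1250 uM, which is a limit of the assay and not a number. Compound 3, with the structure `O=C1C=CCC(/C=C/c2ccccc2C(F)(F)F)N1`, gives 249 uM in this assay. Among the measured compounds shown here, the step of an at least 5.0-fold lower number from compound 2 to compound 3 (0.70 log units; beyond the scatter) is the only single change measured within the lactam series, and its size remains open-ended because of the limit of > 1250 uM in this assay, at which 1 of the 3 values shown sits.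

Compound 4, with the structure `COc1ccc(/C=C/C2CC=CC(=O)N2)cc1`, differs from compound 2 by methoxy in place of hydrogen on an aromatic carbon. For the measured compounds named here, no measured step puts a methoxy in place of hydrogen on this core, and compound 1 differs from compound 4 in more than one place, so its value cannot be read as a step. The trifluoromethyl step from compound 2 to compound 3 concerns a different group at a different place and gives no direct guidance. The expectation for compound 4 is therefore a number close to the limit of compound 2, with an expected step of an at least 1.7-fold lower number from compound 2 to compound 4 (0.25 log units; that floor lies within the scatter) that may not exceed the scatter. Compound 4 is estimated at 700 uM, in the range 150 uM to 2500 uM.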

Compound 4, concentration for growth inhibition (reported as GI): > 1090 uM
Compound 4: no number, only a limit (the forecaster's own chance of this, stated with the estimate: 50%); at least 1.5-fold (0.19 log units) between middle value and limit.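

In this assay compound 4 gives > 1090 uM, which is a limit of the assay and not a number. Among the compounds shown here, compound 2 also stands at a limit, so no step from compound 2 to compound 4 can be read. The compounds shown leave open whether methoxy in place of hydrogen changes growth inhibition on the shared core.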